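Thiourea series: cytotoxicity notes on a piperazine substituent change

This account rests on a few compounds, and the source may have more. Where it says the series, first, only, none or still open, it means among the compounds named here.

Measured in a toxicity assay on RAW264.7 cells (Mus musculus) for cytotoxicity, read by MTT assay, with a stated time of 24 h; a higher number here means that more compound is tolerated, a lower number that less compound is tolerated:
compound 1 `O=C(O)c1ccc(NC(=S)NCc2ccccc2)cc1O` gives 197000 nM
compound 2 `S=C(Nc1ccccc1)N1CCN(c2ncccn2)CC1` gives >= 200000 nM
compound 3 `S=C(NCc1ccccc1)N1CCN(c2ncccn2)CC1` gives 50900 nM

Compound 2 sits at a limit of the assay, not at a number (the limit of >= 200000 nM in this assay, at which 1 of the 3 values shown sits). Of the three values shown it is the one that is only a limit, so it can only be said that compound 2 is tolerated at least up to that point.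

Within the data shown here, the one step measured in this set runs an at least 3.9-fold lower number from compound 2 to compound 3 (0.59 log units; beyond the scatter), a change on the amide-type nitrogen. Compound 4 `CCCCN1CCN(C(=S)Nc2ccccc2)CC1` differs from compound 2 elsewhere: butyl in place of pyrimidin-2-yl on an amine nitrogen in a ring. Among the measured compounds shown here, no measured step touches that ring nitrogen, so the step from compound 2 to compound 3 gives no direction for it, and the expected change is set mainly by the width of the scatter and the unknown distance of compound 2 beyond its limit.

Compound 4 is therefore estimated at 120000 nM, with a range from 40000 nM to 200000 nM, which is expected to mean an at least 1.6-fold lower number from compound 2 to compound 4 (0.22 log units; that floor lies within the scatter).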

Compound 4, half-maximal cytotoxic concentration: >= 200000 nM
Compound 4: no number, only a limit (the forecaster's own chance of this, stated with the estimate: 35%); middle value at least 1.6-fold (0.22 log units) away from the limit.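

Compound 4 gives >= 200000 nM, which is a limit and not a number. Compound 2 stands at the same limit, so no step can be read between compound 2 and compound 4: the limit of >= 200000 nM in this assay, at which 2 of the 4 values shown sit.

The compounds shown leave open how far compound 2 and compound 4 each lie beyond that limit, and so whether butyl in place of pyrimidin-2-yl changes the tolerated concentration.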